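A few compounds are considered here, and "the series" means these few. Any claim that something is new, unique, unknown or untested is made for them only; others in the source may bear on it.

Measured so far in a functional assay on blood (Homo sapiens) for inhibition; a higher number here means a weaker inhibitor, a lower number a stronger inhibitor:
compound 1 `CCC(C)CNc1cc(-c2[nH]c(SC)nc2-c2ccc(F)cc2)ccn1` — 2760 nM
compound 2 `CSc1nc(-c2ccc(F)cc2)c(-c2ccnc(NC3CCCCC3C)c2)[nH]1` — 136 nM
compound 3 `CSc1nc(-c2ccc(F)cc2)c(-c2ccnc(NCC3CCCCC3)c2)[nH]1` — "not determined" (no result reported)

Compound 1 has the highest of the two numbers in this assay; compound 2 stands nearest, with a 20-fold lower number from compound 1 to compound 2 (1.31 log units; beyond the scatter) from 2-methylcyclohexyl in place of 2-methylbutyl on a nitrogen on an aromatic ring. Compound 4 `CCC(Nc1cc(-c2[nH]c(SC)nc2-c2ccc(F)cc2)ccn1)c1ccccc1` is not yet measured. It differs from compound 1 as 1-phenylpropyl in place of 2-methylbutyl on a nitrogen on an aromatic ring. Within the data shown here, the only step that bears on it is the one from compound 1 to compound 2, where a ring entered in the same place and the number fell sharply. For compound 4 a lower number is expected too, with an expected step of a 4.6-fold lower number from compound 1 to compound 4 (0.66 log units; beyond the scatter), which is smaller than the measured one, as that measured change rests on a single pair. Compound 4 is estimated at 600 nM, within 150 nM to 2500 nM.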

Compound 4, half-maximal inhibitory concentration: 7640 nM
Compound 4: middle estimate off by 13-fold (1.10 log units), on the low side, outside the stated range (above it).
By their numbers in this assay, from the lowest: compound 2; then compound 1; then compound 4.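

In this assay a ring on this nitrogen does not by itself lower the number, since 1-phenylpropyl gives a 2.8-fold higher number from compound 1 to compound 4 (0.44 log units; beyond the scatter) and so moves the opposite way to 2-methylcyclohexyl. The two ring-bearing groups lie far apart, with a 56-fold higher number from compound 2 to compound 4 (1.75 log units; beyond the scatter), so at this position the identity of the ring-bearing group matters, not just the presence of a ring. Nothing available explains this gap. Open, from the compounds shown here alone, is whether a benzyl or cyclopentyl group on this nitrogen would track compound 2 or compound 4. Also open, going by these compounds, is how a hydroxyl on the cyclohexyl ring of compound 2 would shift the number.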